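The source may report more compounds than this note shows. Statements on the series, on what has been measured and on what is new or still open speak of the compounds shown alone.

In a functional assay on A549 cells (Homo sapiens) for cytotoxicity, read by MTT assay, with a stated time of 72 h (on this read-out higher numbers stand for weaker inhibition and lower numbers for stronger inhibition), compound 1 `CN(C)CCn1cnnc1-c1cc(Oc2ccc(NC(=O)N/N=C/c3ccc(Cl)cc3Cl)cc2F)ccn1` gives 810 nM, compound 2 `COc1ccc(/C=N/NC(=O)Nc2ccc(Oc3ccnc(-c4nncn4CCN(C)C)c3)c(F)c2)c(OC)c1` gives 2820 nM, and compound 3 `CN(C)CCn1cnnc1-c1cc(Oc2ccc(NC(=O)N/N=C/c3ccc(F)cc3)cc2F)ccn1` gives 1790 nM. Compound 3 thus holds the second highest of the three numbers; its nearest neighbour is compound 2, a gap within the scatter, while the step of a 2.2-fold higher number from compound 1 to compound 3 (0.34 log units; beyond the scatter) lies beyond it. Compound 4 `CN(C)CCn1cnnc1-c1cc(Oc2ccc(NC(=O)N/N=C/c3ccc(O)c(O)c3)cc2F)ccn1` differs from compound 3 by 3,4-dihydroxyphenyl in place of 4-fluorophenyl on a carbon with a double bond to nitrogen. Every step seen so far alters the same aryl group on that carbon: a 3.5-fold higher number from compound 1 to compound 2 (0.54 log units; beyond the scatter), a 2.2-fold higher number from compound 1 to compound 3 (0.34 log units; beyond the scatter) and a 1.6-fold lower number from compound 2 to compound 3 (0.20 log units; within the scatter), none larger than modest. A modest change in this assay is therefore expected for compound 4 as well, with no clear direction. The step of a 1.4-fold higher number from compound 3 to compound 4 (0.15 log units; within the scatter) is expected to remain small. Compound 4 is estimated at 2500 nM, within 900 nM to 7000 nM.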

Compound 4, half-maximal inhibitory concentration: > 100000 nM
Compound 4: no number, only a limit; the forecaster's own chance of this, stated with the estimate: 5%; middle value at least 40-fold (1.60 log units) from the limit.
By their numbers in this assay, from the lowest: compound 1; then compounds 3 and 2 (each within the scatter of the next). At a limit, above all of these: compound 4.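

In this assay, the aryl group on a carbon with a double bond to nitrogen turns out to matter far more than the earlier modest steps suggested: an at least 55-fold higher number from compound 3 to compound 4 (1.74 log units; beyond the scatter), an at least 35-fold higher number from compound 2 to compound 4 (1.54 log units; beyond the scatter) and an at least 120-fold higher number from compound 1 to compound 4 (2.09 log units; beyond the scatter), all large. These steps rest on a limit of the assay for compound 4, not a number: the limit of > 100000 nM in this assay, at which 1 of the 4 values shown sits. Of the four aryl groups shown, only 3,4-dihydroxyphenyl carries hydroxyl groups, and only it reaches this limit. Still open, on these data alone, is whether a 4-hydroxyphenyl or a 3,4-dimethoxyphenyl group would behave like 3,4-dihydroxyphenyl or like 4-fluorophenyl.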